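Extending a Butylamino Chain in Two Matched Pairs

The source may hold more compounds than are shown below. What is called first, only, known or untested is meant among the compounds shown, and "the series" means these compounds.

This account follows a small set of compounds tested in an assay on HEK293 cells for inhibition of solute carrier family 12 member 2 (Homo sapiens), read by fluorescence, with a stated time of 30 min, tested at 100 uM; a lower number here means a weaker effect, a higher number a stronger effect of the compound at the concentration tested. Compound 1 `CCCCNc1ccc([N+](=O)[O-])cc1S(N)(=O)=O` gives 4.7% in this assay. Compound 2 `CCCCCCNc1ccc([N+](=O)[O-])cc1S(N)(=O)=O` carries a longer chain; its change from compound 1 is ethyl in place of hydrogen on a saturated chain carbon, four bonds along the chain from a nitrogen on an aromatic ring. In this assay compound 2 gives 3.8%, so the step of a number 0.9 percentage points lower from compound 1 to compound 2 (within the scatter) is small. Compound 3 `CCCCNc1ccc(C(=O)O)cc1S(N)(=O)=O` differs from compound 1 in its core by carboxy in place of nitro on an aromatic carbon; in this assay compound 3 gives 6.4%, and the step of a number 1.7 percentage points higher from compound 1 to compound 3 (within the scatter) likewise stays within the usual spread of such measurements. All three numbers lie close together and none can be ranked against the others.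

Compound 4 `CCCCCCNc1ccc(C(=O)O)cc1S(N)(=O)=O` has not been measured. It is related to compound 3 by ethyl in place of hydrogen on a saturated chain carbon, four bonds along the chain from a nitrogen on an aromatic ring, the same change that links compound 1 to compound 2, and it sits at the same place on the chain, four bonds along from the nitrogen on the aromatic ring. The two cores differ by carboxy in place of nitro on an aromatic carbon.

Since the earlier step of a number 0.9 percentage points lower from compound 1 to compound 2 (within the scatter) made hardly any difference, the step from compound 3 to compound 4 is expected to be of similar size, about a number 0.9 percentage points lower from compound 3 to compound 4 (within the scatter). Compound 4 is therefore estimated to give 5.5% in this assay, with a plausible range from -2% to 13%, resting on compound 3 at 6.4% and on the near-flat step seen between compound 1 and compound 2.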

Compound 4, a percentage reported as inhibition, at one concentration (the size of the read-out at that concentration, not a potency): 4.9%
Beside the measured number, compound 4's estimate is 0.6 percentage points above it; measured number inside the range.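

In this assay, the ethyl-for-hydrogen change on the chain gives a number 1.5 percentage points lower from compound 3 to compound 4 (within the scatter), and set beside its earlier counterpart on the nitro core it does not differ: the same change on two cores in this assay, a number 0.9 percentage points lower (within the scatter) from compound 1 to compound 2 and a number 1.5 percentage points lower (within the scatter) from compound 3 to compound 4, 0.6 percentage points apart, within the scatter of two such steps. The carboxy-for-nitro change, read on the longer chain, gives a number 1.1 percentage points higher from compound 2 to compound 4 (within the scatter), and again the two readings do not differ: the same change on two cores in this assay, a number 1.7 percentage points higher (within the scatter) from compound 1 to compound 3 and a number 1.1 percentage points higher (within the scatter) from compound 2 to compound 4, 0.6 percentage points apart, within the scatter of two such steps. Both changes therefore stay small on either side of the square and nothing separates the paired steps, but every step lies within the scatter, so this is agreement between steps too small to read and does not show that a real effect of either change carries over from one core to another.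

The compounds shown leave open whether a shorter chain on the nitrogen, or an amide or a nitrile in place of the carboxy or nitro, would move the number beyond the scatter. They also leave open how these four compounds would compare as potencies, as the read-out here gives only the size of the effect at one concentration.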